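The source may report more compounds than this note shows. Statements on the series, on what has been measured and on what is new or still open speak of the compounds shown alone.

Values in an ADME assay on HEK293 cells (Homo sapiens) for cytotoxicity, read by reporter gene assay and resazurin assay, with a stated time of 48 h; a higher number here means that more compound is tolerated, a lower number that less compound is tolerated:
- compound 1 `O=C(Nc1ccc(Sc2nc3ccccc3s2)c(Cl)c1)c1cccc(Br)c1O`: 64000 nM
- compound 2 `O=C(Nc1ccc(Sc2nc3ccccc3s2)c(Cl)c1)c1cc(Br)cc(Br)c1O`: 76000 nM
- compound 3 `O=C(Nc1ccc(Sc2nc3ccccc3s2)cc1)c1cc(Br)cc(Br)c1O`: 66000 nM

Compound 2 is not separated from the other two, as both measured steps show: a 1.2-fold higher number from compound 1 to compound 2 (0.07 log units; within the scatter), and a 1.2-fold lower number from compound 2 to compound 3 (0.06 log units; within the scatter). Compound 4 `O=C(Nc1ccc(Sc2nc3ccccc3s2)c(Cl)c1)c1cc(Br)ccc1O` has hydrogen in place of bromo on an aromatic carbon of compound 2, ortho to a hydroxy group: hydrogen in place of bromo on an aromatic carbon. For the measured compounds named here, the nearest precedent is the first step, which exchanges the same two substituents on the same ring, though at a different carbon. The second step exchanges hydrogen and chloro elsewhere in the molecule. Neither leaves the scatter, so no shift in either direction is expected in this assay. The expected change is a 1.1-fold lower number from compound 2 to compound 4 (0.05 log units; within the scatter). For compound 4 the estimate is 67000 nM, with an expected range of 40000 nM to 105000 nM.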

Compound 4, half-maximal cytotoxic concentration: 45000 nM
For compound 4 the middle estimate is 1.5-fold (0.17 log units) above the measured one, within the range that was stated.
By their numbers in this assay, from the lowest: compounds 4, 1, 3 and 2 (each within the scatter of the next).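

In this assay, hydrogen in place of bromo ortho to the hydroxy group gives a 1.7-fold lower number from compound 2 to compound 4 (0.23 log units; within the scatter), so 3,5-dibromo-2-hydroxyphenyl to 5-bromo-2-hydroxyphenyl does not separate these two compounds. Exchanging the single bromo's place, 5-bromo-2-hydroxyphenyl for 3-bromo-2-hydroxyphenyl, gives a 1.4-fold lower number from compound 1 to compound 4 (0.15 log units; within the scatter), which also stays unresolved. No measurement available here bears on the reason for these numbers. Open, going by these compounds, is how this position behaves with an amine or a carboxylic acid in place of hydrogen, as only bromo and hydrogen appear there.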